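This account rests on a few compounds, and the source may have more. Where it says the series, first, only, none or still open, it means among the compounds named here.

Compound 1, `O=C(CCl)Nc1cc([N+](=O)[O-])ccc1N1CCCCC1`: 8.1%
Compound 2, `O=C1CN(CCCCCCCl)c2ccc([N+](=O)[O-])cc2N1`: 16.6%
Compound 3, `CN1CC(=O)N(C)c2cc([N+](=O)[O-])ccc21`: 0%

In a functional assay on J774 cells (Mus musculus) for cytotoxicity, tested at 1 ug/mL (on this read-out higher numbers stand for a stronger effect at the one concentration tested and lower numbers for a weaker effect), compound 3 gives 0%, the lowest of the three numbers. Its nearest neighbour is compound 1, whose value of 8.1% lies within the usual scatter of the read-out, so nothing separates the two. Compound 2 stands furthest away: its 16.6% lies beyond the scatter above compound 3.

Compound 4, `CN1C(=O)CN(CCCCCCl)c2ccc([N+](=O)[O-])cc21`, has not yet been measured. It differs from compound 3 by the change (4-chlorobutyl in place of hydrogen on a saturated chain carbon bound to a nitrogen on an aromatic ring in a ring). Within the data shown here, no pair of measured compounds shares a single-point step, so no direct precedent for this change exists. Among the measured compounds shown here, the only guide is that compound 2, the one member carrying a chloroalkyl chain, returns the highest number, while compound 3 without such a chain returns the lowest. On that slim basis a modest upward step is expected, a number 9 percentage points higher from compound 3 to compound 4 (within the scatter), with the real possibility that it stays within the scatter. Compound 4 is therefore estimated at 9%, in the range 0% to 25%.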

Compound 4, a percentage reported as activity, at one concentration (the size of the read-out at that concentration, not a potency): 0%
Beside the measured number, compound 4's estimate is 9 percentage points above it; the range from low to high includes it.
By their numbers in this assay, from the lowest: compounds 3, 4, 1 and 2 (each within the scatter of the next, the first and the last beyond it).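

Among these compounds, the first step that can be read in one place shows that, in this assay, 4-chlorobutyl in place of hydrogen on a saturated chain carbon bound to a nitrogen on an aromatic ring in a ring gives no change at the digits printed from compound 3 to compound 4 (within the scatter). On this core, then, adding this chloroalkyl chain at this position does not by itself raise the read-out, and since compound 3 already gives 0%, the step could not have revealed any weakening. Nothing given here bears on why the number stays where it is.

From the compounds shown here alone, it remains open whether a longer chain, or an amine or a carboxylic acid in place of the chlorine at the chain end, would move the number at this position. Whether the hydrogen can be replaced by a shorter chloroalkyl chain with the same outcome also stays unanswered.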